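The source may report more compounds than this note shows. Statements on the series, on what has been measured and on what is new or still open speak of the compounds shown alone.

This study follows a small family of compounds built on one shared core, all tested in a functional assay on the whole organism for inhibition, with Rattus norvegicus as the target, read by paw edema, with stated times of 1 h and 3 h, at a dose of 50 mg/kg by the oral route; a lower number here means less inhibition, a higher number more inhibition at the dose given (going by the name of the read-out). Compound 1 `C/C(=N\OCC(=O)O)c1ccccc1O` opens the set. In this assay compound 1 gives < 20%, which is a limit of the assay and not a number. Compound 2 `C/C(=N\OCC(=O)O)c1ccccc1C(=O)O` is the next member, reached by the step that the two limits leave unreadable from compound 1 to compound 2. In this assay compound 2 gives < 20%, again a limit. Compound 3 `C/C(=N\OCC(=O)O)c1ccc(O)cc1` completes the measured set. In this assay compound 3 gives < 20%, also a limit. Compound 3 thus stands exactly where every measured compound stands: at the limit of < 20% in this assay, at which 3 of the 3 values shown sit.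

The step of interest leads from compound 3 to compound 4 `C/C(=N\OCC(=O)O)c1ccc(N(C)C)cc1`. (dimethylamino in place of hydroxy on an aromatic carbon). Among the compounds with values here, no measured step bears directly on this change: the only step between measured compounds, from compound 1 to compound 2, cannot be sized, since both of its ends sit at the limit of < 20% in this assay, at which 3 of the 3 values shown sit, and no measured pair swaps a hydroxy for a dimethylamino. With nothing in the measured compounds pointing to a gain, the step is expected to be nothing beyond the scatter, a step that the limit leaves unreadable from compound 3 to compound 4. Compound 4 is therefore expected to give about 15% in this assay, most likely between 0% and 35%.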

Compound 4, a percentage reported as inhibition, in the whole organism at one dose (the size of the read-out at that dose, not a potency): < 20%
Compound 4 was reported as a limit (the forecaster's own chance of this, stated with the estimate: 60%); the middle value is on the limit's open side.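

In this assay compound 4 gives < 20% as a limit of the assay and not a number. Within the data shown here, compound 3 and compound 4 therefore both sit at a limit, so no step between them can be read: the limit of < 20% in this assay, at which 4 of the 4 values shown sit. The compounds shown leave open whether dimethylamino in place of hydroxy changes inhibition at all, and whether any member of this family gives a readable value.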